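From a Hydroxy Group to a Methyl on the Aryl Ring

A few compounds are considered here, and "the series" means these few. Any claim that something is new, unique, unknown or untested is made for them only; others in the source may bear on it.

Of the compounds shown here, three sharing one core have been measured in a functional assay on OVCAR-3 cells (Homo sapiens) for inhibition, read by MTT assay, with a stated time of 24 h; a higher number here means a weaker inhibitor, a lower number a stronger inhibitor. Compound 1 `CC1(C)[C@H]2CC[C@]1(C)N(Cc1cn(-c3ccc(Cl)cc3)nn1)C(=O)C2` gives 160 nM, compound 2 `CC1(C)[C@H]2CC[C@]1(C)N(Cc1cn(-c3ccccc3O)nn1)C(=O)C2` gives 90 nM, and compound 3 `CC1(C)[C@H]2CC[C@]1(C)N(Cc1cn(-c3ccc(O)cc3)nn1)C(=O)C2` gives 410 nM, the highest of the three numbers. The steps of a 2.6-fold higher number from compound 1 to compound 3 (0.41 log units; beyond the scatter) and a 4.6-fold higher number from compound 2 to compound 3 (0.66 log units; beyond the scatter) both leave compound 3 at the weak end. Compound 4 `Cc1cccc(-n2cc(CN3C(=O)C[C@@H]4CC[C@@]3(C)C4(C)C)nn2)c1` carries 3-methylphenyl in place of 4-hydroxyphenyl on an aromatic nitrogen. Going by the values given here, no measured step places a methyl on that ring, but the step of a 2.6-fold higher number from compound 1 to compound 3 (0.41 log units; beyond the scatter) shows a hydroxy in place of chloro raising the number, so removing the hydroxy is expected to lower it modestly. Compound 4 is therefore expected to give 180 nM, in a range from 70 nM to 500 nM. The step of a 2.3-fold lower number from compound 3 to compound 4 (0.36 log units; beyond the scatter) is expected to lie beyond the scatter.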

Compound 4, half-maximal inhibitory concentration: 160 nM
Compound 4: the middle estimate sits 1.1-fold (0.05 log units) above what was measured; the range from low to high includes it.
By their numbers in this assay, from the lowest: compounds 2, 1 and 4 (each within the scatter of the next); then compound 3.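

The move from 4-hydroxyphenyl to 3-methylphenyl on the aromatic nitrogen gives a 2.6-fold lower number from compound 3 to compound 4 (0.41 log units; beyond the scatter) and takes the compound out of the weak end of the series. The other two steps, a 1.8-fold higher number from compound 2 to compound 4 (0.25 log units; within the scatter) and no change at the digits printed from compound 1 to compound 4 (within the scatter), show that 3-methylphenyl stands level with 2-hydroxyphenyl and 4-chlorophenyl. Nothing available explains these differences.

Because the group and its place on the ring change together in this step, the two effects remain unseparated. Also open, going by these compounds, is whether a 4-methylphenyl ring, or an aryl ring bearing an amine or a carboxylic acid, would join this level group or fall with compound 3.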